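From methylsulfonyl to phenylsulfonyl on the shared core

A few compounds are considered here, and "the series" means these few. Any claim that something is new, unique, unknown or untested is made for them only; others in the source may bear on it.

Going by the values given here, compound 2 `CS(=O)(=O)n1cc(CCCC(=O)NCCCn2ccnc2)c2ccccc21` is one of two compounds measured in an assay on isolated protein for activation of Insulin-degrading enzyme (Homo sapiens), read by fluorescence, with stated times of 10 min and 20 min (a lower number here means that less compound is needed, a higher number that more compound is needed for the effect), where compound 2 gives 26900 nM. Among the compounds with values here, the only comparison is compound 1 `O=C(CCCc1cn(C(=O)c2cccs2)c2ccccc12)NCCCn1ccnc1`, which in this assay gives 21400 nM; the step of a 1.3-fold higher number from compound 1 to compound 2 (0.10 log units; within the scatter) swaps a thiophenyl carbonyl group for a methylsulfonyl on the aromatic nitrogen and stays within the scatter, so the two numbers cannot be told apart. Compound 3 `O=C(CCCc1cn(S(=O)(=O)c2ccccc2)c2ccccc12)NCCCn1ccnc1` has not been measured. It differs from compound 2 by phenyl in place of methyl on a sulfonyl sulfur. Within the data shown here, no measured step tests this exact change; the one step available, from compound 1 to compound 2, shows that exchanging the group on the aromatic nitrogen left the number within the scatter. The step of a 1.2-fold lower number from compound 2 to compound 3 (0.09 log units; within the scatter) is therefore expected to stay within the scatter as well. The estimate for compound 3 in this assay is 22000 nM, with a range from 8000 nM to 60000 nM.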

Compound 3, half-maximal effective concentration: 13200 nM
Beside the measured number, compound 3's estimate is 1.7-fold (0.22 log units) above it, and the stated range covers the measured number.
By their numbers in this assay, from the lowest: compounds 3, 1 and 2 (each within the scatter of the next, the first and the last beyond it).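

In this assay, going by these compounds alone, the group on the sulfonyl sulfur now proves able to move the number: phenyl in place of methyl gives the step (a 2.0-fold lower number from compound 2 to compound 3 (0.31 log units; beyond the scatter)), the only sulfonyl comparison here and the first step in this set to pass the usual scatter, though only modestly. The choice of group on the aromatic nitrogen still does not separate every pair, as phenylsulfonyl in place of (thiophen-2-yl)carbonyl gives the step (a 1.6-fold lower number from compound 1 to compound 3 (0.21 log units; within the scatter)), so compound 1 and compound 3 cannot be told apart. Nothing in the available data explains the step from methyl to phenyl.

One step cannot show whether the aromatic ring itself matters or whether an ethyl or a longer carbon chain on the sulfur would do the same. Going by these compounds, it also remains open how a phenyl ring carrying an amine or a carboxylic acid would behave.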